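The source may hold more compounds than are shown below. What is called first, only, known or untested is meant among the compounds shown, and "the series" means these compounds.

The study reports two measured compounds in a functional assay on the whole organism (strain NMRI) with Mus musculus as the target, with a stated time of 4 h (on this read-out higher numbers stand for an effect only at larger amounts of compound and lower numbers for an effect already at smaller amounts), and one compound that still awaits testing. Compound 1 `COc1ccc(Cn2cc(CO/N=C/c3c(-c4ccccc4)nc4c(C)cccn34)nn2)cc1` carries the higher of the two numbers: in this assay compound 1 gives 100 mg/kg. Compound 2 `C#CCO/N=C/c1c(-c2ccc(C)cc2)nc2ccc(Br)cn12` stands lowest of the two, and in this assay compound 2 gives 40 mg/kg, a reading separated from that of compound 1 by a gap beyond the usual scatter.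

Compound 3 `Cc1ccc(-c2nc3ccc(Br)cn3c2/C=N/O)cc1` has not yet been tested in this assay. It differs from compound 2 in a single place: hydrogen in place of propargyl on an oxygen. The same difference, cut one bond further out, reads propargyloxy to hydroxy. Within the data shown here, no measured pair of compounds shows what this kind of change does on this read-out, so there is no step to lean on, and the estimate rests on compound 2 alone.

The change from propargyl to hydrogen on the oxygen is expected to shift the result of this assay only modestly, and the expected step is a 1.3-fold higher number from compound 2 to compound 3 (0.10 log units; within the scatter), with no clear direction beyond the scatter. Compound 3 is therefore expected to give about 50 mg/kg in this assay, within a range from 20 mg/kg to 130 mg/kg.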

Compound 3, minimum effective dose: 20 mg/kg
Compound 3: middle estimate off by 2.5-fold (0.40 log units), on the high side; low and high end bracket the measured number.
By their numbers in this assay, from the lowest: compounds 3 and 2 (each within the scatter of the next); then compound 1.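

Among these compounds, the first step between compounds that differ in one place concerns the group on an oxygen whose other neighbour is a double-bonded nitrogen: in this assay, hydrogen in place of propargyl gives a 2.0-fold lower number from compound 2 to compound 3 (0.30 log units; within the scatter). At this position, then, the whole propargyl group, with its 3 carbon atoms and its triple bond, can give way to hydrogen without the reading moving beyond the usual scatter, so the propargyloxy and hydroxy forms cannot be told apart on this read-out. Nothing presented here explains this tolerance.

This single step spans only the two ends of a short series, and it leaves open whether a methyl group, or a longer chain ending in an amine or a carboxylic acid, on the same oxygen would also stay within the scatter. Among the compounds shown here, compound 1 differs from compound 2 and compound 3 in more than one place, so no step shows what its larger group on the oxygen contributes on its own, and the role of the other substituents on the core remains unresolved.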